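Ethylsulfonyl in place of the difluorobenzyl arm

This account rests on a few compounds, and the source may have more. Where it says the series, first, only, none or still open, it means among the compounds named here.

Three compounds of the series share one core and differ only in the group on an aromatic carbon of the five-membered aromatic ring with 2 nitrogen and 1 oxygen. Compound 1 `CCCCSc1nnc(COc2cc(C)c3c(C)cc(=O)oc3c2)o1` carries a propyl and compound 2 `CCCCCCSc1nnc(COc2cc(C)c3c(C)cc(=O)oc3c2)o1` a pentyl on the saturated chain carbon bound to a sulfur; compound 3 `Cc1cc(OCc2nnc(SCc3ccc(F)c(F)c3)o2)cc2oc(=O)cc(C)c12` carries a 3,4-difluorophenyl there. Going by the values given here, in a functional assay on MCF7 cells (Homo sapiens) for antiproliferative activity, read by MTT assay, with a stated time of 24 h (a lower number here means a stronger inhibitor, a higher number a weaker inhibitor), compound 3 gives 33300 nM, the only number obtained in the set. For compound 1 the assay returns only a limit, > 100000 nM. For compound 2 it likewise returns only a limit, > 100000 nM. Both values are the limit of > 100000 nM in this assay, at which 2 of the 3 values shown sit. The step that the two limits leave unreadable from compound 1 to compound 2 is thus unreadable, whereas an at least 3.0-fold lower number from compound 1 to compound 3 (0.47 log units; beyond the scatter) and an at least 3.0-fold lower number from compound 2 to compound 3 (0.47 log units; beyond the scatter) show that the 3,4-difluorophenyl on the chain carbon bound to a sulfur brings the number into the measurable range.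

Compound 4 `CCS(=O)(=O)c1nnc(COc2cc(C)c3c(C)cc(=O)oc3c2)o1` is not yet measured. Against compound 3 the change is ethylsulfonyl in place of (3,4-difluorobenzyl)sulfanyl on an aromatic carbon. This removes the 3,4-difluorophenyl arm that set compound 3 apart and installs a small group, closer in size to the chains of compound 1 and compound 2. The readable steps of an at least 3.0-fold lower number from compound 1 to compound 3 (0.47 log units; beyond the scatter) and an at least 3.0-fold lower number from compound 2 to compound 3 (0.47 log units; beyond the scatter) bear on it in reverse, so a return toward the limit is expected. The expected step is a 3.0-fold higher number from compound 3 to compound 4 (0.48 log units; beyond the scatter). Compound 4 is estimated at 100000 nM, between 30000 nM and 300000 nM, with a fair chance that only a limit is reported.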

Compound 4, half-maximal inhibitory concentration: > 100000 nM
Compound 4: a limit, no number; the forecaster's own chance of this, stated with the estimate: 60%; the middle value lies on the limit itself.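

Up to now the position had been probed only through groups attached by a sulfanyl sulfur; the change to ethylsulfonyl on the aromatic carbon tests a different attachment and gives an at least 3.0-fold higher number from compound 3 to compound 4 (0.47 log units; beyond the scatter) in this assay, so the gain seen with compound 3 does not carry over to this small sulfonyl group. The steps linking compound 4 to compound 1 and compound 2 cannot be read, so ethylsulfonyl cannot be ranked against butylsulfanyl or hexylsulfanyl. Among the four compounds, only the (3,4-difluorobenzyl)sulfanyl group of compound 3 gives a number, and the other three compounds stay at a limit: the limit of > 100000 nM in this assay, at which 3 of the 4 values shown sit.

Compound 4 loses the difluorophenyl ring and changes the sulfur in one step, so the compounds shown do not tell which of the two changes accounts for the return to the limit; a (3,4-difluorobenzyl)sulfonyl group or a plain benzylsulfanyl group would divide the question. Also open, from the compounds shown here alone, is whether the position tolerates any attachment without sulfur, such as an amine carrying the same 3,4-difluorobenzyl group.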